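This account rests on a few compounds, and the source may have more. Where it says the series, first, only, none or still open, it means among the compounds named here.

Compound 1 `CNc1nc(SC)nc2c1ncn2[C@@H]1C[C@@H](O)[C@H](CO)O1` gives 186 uM in a functional assay on NALL-1 cells (Homo sapiens); a higher number here means a weaker inhibitor, a lower number a stronger inhibitor. Compound 3 `CNc1nc(Br)nc2c1ncn2[C@@H]1C[C@@H](O)[C@H](CO)O1` gives 230 uM. Compound 2 `CN(C)c1nc(N)c2ncn([C@@H]3C[C@@H](O)[C@H](CO)O3)c2n1` gives only the assay limit of > 300 uM.

Compound 2 therefore stands at the limit of > 300 uM in this assay, at which 1 of the 3 values shown sits, with no number of its own. Compound 4 `CSc1nc(N)c2ncn([C@@H]3C[C@@H](O)[C@H](CO)O3)c2n1` differs from compound 2 in that (methylsulfanyl in place of dimethylamino on an aromatic carbon). Going by the values given here, the only measured step at that aromatic carbon, a 1.2-fold higher number from compound 1 to compound 3 (0.09 log units; within the scatter), stays within the scatter, but it concerns bromo and methylsulfanyl rather than dimethylamino, so it bears on the present change only indirectly. Compound 1 carries methylsulfanyl at the same place and gives 186 uM. Compound 4 is expected to give 200 uM in this assay, with a range from 80 uM to 400 uM. The expected step is an at least 1.5-fold lower number from compound 2 to compound 4 (0.17 log units; that floor lies within the scatter), toward a measurable number.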

Compound 4, concentration for 50% inhibition: 96 uM
Beside the measured number, compound 4's estimate is 2.1-fold (0.32 log units) above it, and the stated range covers the measured number.
By their numbers in this assay, from the lowest: compounds 4, 1 and 3 (each within the scatter of the next, the first and the last beyond it). At a limit, above all of these: compound 2.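

In this assay, going by these compounds alone, methylsulfanyl in place of dimethylamino on the aromatic carbon between two ring nitrogen atoms gives the first step at this position that lies beyond the scatter (an at least 3.1-fold lower number from compound 2 to compound 4 (0.49 log units; beyond the scatter)). With methylsulfanyl in place, hydrogen in place of methyl on the ring-bound nitrogen stays within the scatter (a 1.9-fold lower number from compound 1 to compound 4 (0.29 log units; within the scatter)). The size of the first step is only a floor, and compound 2 has a limit rather than a number: the limit of > 300 uM in this assay, at which 1 of the 4 values shown sits.

The compounds shown leave open how a longer chain on the sulfur, such as benzylsulfanyl, would read at this carbon. They also leave open how a carboxylic acid would read there.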